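Cytotoxicity on Vero cells across the amide-bearing series

The source may report more compounds than this note shows. Statements on the series, on what has been measured and on what is new or still open speak of the compounds shown alone.

Compound 3 is `CCCC(=O)N1CCN(c2nc(=O)c3cc(C(F)(F)F)cc([N+](=O)[O-])c3s2)CC1`. In an ADME assay on Vero cells (Chlorocebus sabaeus) for cytotoxicity, read by MTT assay, with a stated time of 72 h (a lower number here means that less compound is tolerated, a higher number that more compound is tolerated), compound 3 gives > 125000 nM, which is a limit of the assay and not a number. Compound 1 is `O=C(c1cccc(F)c1)N1CCN(c2nc(=O)c3cc(C(F)(F)F)cc([N+](=O)[O-])c3s2)CC1`. In this assay compound 1 gives > 125000 nM, again a limit. Compound 2 is `CC1COC2(CCN(c3nc(=O)c4cc(C(F)(F)F)cc([N+](=O)[O-])c4s3)CC2)O1`. In this assay compound 2 gives > 125000 nM, also a limit. Compound 3 thus stands with the other two at the limit of > 125000 nM in this assay, at which 3 of the 3 values shown sit, and no measured value separates any of the three.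

Among the measured compounds shown here, the single comparison between measured compounds that touches the carbonyl carbon, a step that the two limits leave unreadable from compound 1 to compound 3, cannot be read because both of its ends sit at the limit of > 125000 nM in this assay, at which 3 of the 3 values shown sit.

Compound 4 is `O=C(c1ccccc1Cl)N1CCN(c2nc(=O)c3cc(C(F)(F)F)cc([N+](=O)[O-])c3s2)CC1`. The change from compound 3 to compound 4 is 2-chlorophenyl in place of propyl on a carbonyl carbon. Compound 1 already carries a fluorinated phenyl ring on this carbonyl carbon and remains at the limit of > 125000 nM in this assay, at which 3 of the 3 values shown sit, so a ring there has not yet brought measurable cytotoxicity. For compound 4 the expected step is therefore none beyond the scatter, a step that the limit leaves unreadable from compound 3 to compound 4. Compound 4 is estimated at 150000 nM, with a range from 60000 nM to 400000 nM, and most likely it too will be reported only as a limit.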

Compound 4, half-maximal cytotoxic concentration: > 125000 nM
Compound 4 ended at the assay's limit; the forecaster's own chance of this, stated with the estimate: 85%; the middle value is on the limit's open side.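

In this assay compound 4 gives > 125000 nM, a limit and not a number, so the steps from compound 3 and from compound 1 to compound 4 cannot be read: the limit of > 125000 nM in this assay, at which 4 of the 4 values shown sit.

The compounds shown leave open the concentration at which any of them becomes cytotoxic, and whether the group on the carbonyl carbon affects it.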